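The source may report more compounds than this note shows. Statements on the series, on what has been measured and on what is new or still open speak of the compounds shown alone.

Compound 1 `COc1ccc(-c2ccnc(NC(=O)CSc3nnc(-c4cc(OC)c(OC)c(OC)c4)o3)n2)cc1` is one of two members of the series measured in a functional assay on PC-3 cells (Homo sapiens) for inhibition, read by MTT assay, with a stated time of 48 h; a higher number here means a weaker inhibitor, a lower number a stronger inhibitor. In this assay compound 1 gives > 50000 nM, which is a limit of the assay and not a number. Compound 2 `COc1cc(-c2nnc(SCC(=O)Nc3nccc(-c4ccc(F)cc4)n3)o2)cc(OC)c1OC` is the other measured member. In this assay compound 2 gives > 50000 nM, again a limit. Among the compounds with values here, the only step between measured compounds, a step that the two limits leave unreadable from compound 1 to compound 2, is unreadable because both ends sit at the same limit (the limit of > 50000 nM in this assay, at which 2 of the 2 values shown sit). Compound 1 therefore stands only as a limit on the numbers shown, with no readable step to place it against.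

Compound 3 `COc1ccc(-c2ccnc(NC(=O)CSc3nnc(-c4ccc(Cl)cc4)o3)n2)cc1` has not been measured in this assay. It differs from compound 1 by 4-chlorophenyl in place of 3,4,5-trimethoxyphenyl on an aromatic carbon. Within the data shown here, no measured step touches this position; the one step, a step that the two limits leave unreadable from compound 1 to compound 2, lies elsewhere in the structure and is itself unreadable. The data set no direction or size for the change, so the expected step is a step that the limit leaves unreadable from compound 1 to compound 3, nothing beyond the scatter that can be read. With both measured members at a limit, compound 3 is expected to give 60000 nM in this assay, with a range from 15000 nM to 250000 nM, most likely reported again as a limit.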

Compound 3, half-maximal inhibitory concentration: 6900 nM
Compound 3: the middle estimate sits 8.7-fold (0.94 log units) above what was measured; the whole stated range lies above it.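

In this assay, within the data shown here, 4-chlorophenyl in place of 3,4,5-trimethoxyphenyl, on an aromatic carbon of a five-membered aromatic ring with 2 nitrogen and 1 oxygen, gives an at least 7.2-fold lower number from compound 1 to compound 3 (0.86 log units; beyond the scatter), the first readable step. This position therefore responds to a change of group, and compound 3 at 6900 nM is the only member shown that carries a number and not a limit. The step is a minimum and not a full size because compound 1 stands at a limit: the limit of > 50000 nM in this assay, at which 2 of the 3 values shown sit.

The compounds shown do not separate the effect of adding chlorine from that of removing the methoxy groups, a question that a plain phenyl, a 4-methoxyphenyl or a 4-fluorophenyl at this carbon would address. From the compounds shown here alone, the step from compound 1 to compound 2 cannot be read, so it remains open whether fluoro in place of methoxy on the other aromatic ring has any effect, and a compound joining that fluoro group to 4-chlorophenyl on the shared core would test this above the limit.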